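The source may hold more compounds than are shown below. What is called first, only, known or untested is meant among the compounds shown, and "the series" means these compounds.

Working notes on the series. In a functional assay on GOTO cells (Homo sapiens) for cytotoxicity, read by MTT assay, with a stated time of 3 days (on this read-out lower numbers stand for stronger inhibition and higher numbers for weaker inhibition), compound 1 (`CCNc1nc(SCc2nc3ccccc3[nH]2)nc(-c2ccccc2)c1C#N`) gives 3.96 nM and compound 2 (`N#Cc1c(NC(N)=O)nc(SCc2nc3ccccc3[nH]2)nc1-c1ccccc1`) gives 11.3 nM, so compound 2 holds the higher of the two numbers. Compound 3 (`CN1CCN(c2nc(SCc3nc4ccccc4[nH]3)nc(-c3ccccc3)c2C#N)CC1`) is still unmeasured. It differs from compound 2 at one place, with 4-methylpiperazin-1-yl in place of ureido on an aromatic carbon, ortho to a cyano group: 4-methylpiperazin-1-yl in place of ureido on an aromatic carbon. For the measured compounds named here, one measured step bears on this, at the same place: a 2.9-fold higher number from compound 1 to compound 2 (0.46 log units; beyond the scatter), which is modest. That single step is thin evidence, and neither of its groups resembles the incoming ring. A step of similar modest size in either direction is possible in this assay, but none beyond the scatter is expected, with a slight lean towards a lower number. The expected step is a 1.4-fold lower number from compound 2 to compound 3 (0.15 log units; within the scatter). For compound 3 the estimate is 8 nM, with an expected range of 2.5 nM to 30 nM.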

Compound 3, half-maximal inhibitory concentration: 3.37 nM
Estimate against measurement, compound 3: 2.4-fold (0.38 log units) above, within the range that was stated.
By their numbers in this assay, from the lowest: compounds 3 and 1 (each within the scatter of the next); then compound 2.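

In this assay, the position on the aromatic carbon ortho to a cyano group accommodates a saturated ring, a point the earlier pair could not show: a 3.4-fold lower number from compound 2 to compound 3 (0.53 log units; beyond the scatter). Against the ethylamino group, the result is a 1.2-fold lower number from compound 1 to compound 3 (0.07 log units; within the scatter), so the 4-methylpiperazin-1-yl and ethylamino groups cannot be told apart here, even though the ring has no hydrogen-bond donors, and among these three compounds only the ureido group of compound 2 stands apart. No measurement bears on why these numbers differ.

The compounds shown leave open whether the ring methyl or the second ring nitrogen contributes, which a morpholine or piperidine ring at this position would test. They also leave open how a primary amine or a carboxylic acid would fare here.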